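This account rests on a few compounds, and the source may have more. Where it says the series, first, only, none or still open, it means among the compounds named here.

Compound 1 `CCN1CCN(c2cc(C)c3cc(NC(=O)c4ccc(OC)cc4)ccc3n2)CC1`: 9000 nM
Compound 2 `Cc1cc(N2CCN(C)CC2)nc2ccc(NC(=O)c3ccc(Cl)c(Cl)c3)cc12`: 6320 nM
Compound 3 `Cc1cc(NCCN2CCCCC2)nc2ccc(NC(=O)c3ccc(Cl)c(Cl)c3)cc12`: 1800 nM

In a functional assay on SK-BR-3 cells (Homo sapiens) for antiproliferative activity, read by MTT assay, with a stated time of 72 h (on this read-out higher numbers stand for weaker inhibition and lower numbers for stronger inhibition), compound 1 gives the highest of the three numbers. Compound 2 sits within the scatter of compound 1, whereas compound 3 lies clearly beyond it toward stronger inhibition. Among the compounds with values here, the only single-site step measured here is a 3.5-fold lower number from compound 2 to compound 3 (0.55 log units; beyond the scatter), and that step concerns the amine attached to the shared core, not the benzamide.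

Compound 4 `CCN1CCN(c2cc(C)c3cc(NC(=O)c4ccc(C)cc4)ccc3n2)CC1` differs from compound 1 by methyl in place of methoxy on an aromatic carbon. Within the data shown here, no measured pair of compounds isolates a change at this position of the benzamide, so the one known step gives no direct guidance; it only shows that the series can move by a modest amount when one group is swapped. With nothing to point either way, compound 4 is expected to stay close to compound 1, with a step of no change at the digits printed from compound 1 to compound 4 (within the scatter) that does not clearly exceed the scatter. Compound 4 is therefore estimated at 9000 nM, with a range from 3000 nM to 27000 nM.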

Compound 4, half-maximal inhibitory concentration: 11400 nM
Estimate against measurement, compound 4: 1.3-fold (0.10 log units) below; measured number inside the range.
By their numbers in this assay, from the lowest: compound 3; then compounds 2, 1 and 4 (each within the scatter of the next).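

The change from 4-methoxyphenyl to 4-methylphenyl gives a 1.3-fold higher number from compound 1 to compound 4 (0.10 log units; within the scatter) in this assay. Within the data shown here, this is the first measured pair that isolates a change at this place on the benzamide, and it shows that on the shared core of compound 1, the methoxy group, with its oxygen and its one hydrogen-bond acceptor, can give way to methyl without a step beyond the scatter. Nothing available bears on why this swap reads as it does.

As far as these compounds go, whether an amine, a carboxylic acid or a butoxy chain in the same place would move the number beyond the scatter remains open. Also open, from the compounds shown here alone, is whether the swap from methoxy to methyl would read the same way on a compound carrying the (2-(piperidin-1-yl)ethyl)amino group of compound 3.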